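A few compounds are considered here, and "the series" means these few. Any claim that something is new, unique, unknown or untested is made for them only; others in the source may bear on it.

In a functional assay (Homo sapiens) for inhibition (on this read-out lower numbers stand for stronger inhibition and higher numbers for weaker inhibition), compound 1 `CCCCOc1ccccc1C(=O)/C=C/c1cc(OC)cc(OC)c1` gives 13000 nM, compound 2 `COc1cc(/C=C/C(=O)c2ccccc2N(C)C)cc(OC)c1` gives 5700 nM and compound 3 `COc1cc(/C=C/C(=O)c2ccccc2F)cc(OC)c1` gives 6000 nM. Compound 3 stands level with compound 2 and has a lower number than compound 1. Next comes compound 4 `COc1cc(/C=C/C(=O)c2cccc(F)c2)cc(OC)c1`, with 3-fluorophenyl in place of 2-fluorophenyl on a carbonyl carbon. For the measured compounds named here, no measured step makes this same change, so the nearest guides are the group exchanges: a 2.3-fold lower number from compound 1 to compound 2 (0.36 log units; beyond the scatter), a 2.2-fold lower number from compound 1 to compound 3 (0.34 log units; beyond the scatter) and a 1.1-fold higher number from compound 2 to compound 3 (0.02 log units; within the scatter). The first two are modest and the third stays within the scatter. In this assay no step beyond the scatter is therefore expected, and the estimated step is a 1.2-fold lower number from compound 3 to compound 4 (0.08 log units; within the scatter). Compound 4 is estimated at 5000 nM, with an expected range of 2000 nM to 13000 nM.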

Compound 4, half-maximal inhibitory concentration: 9200 nM
Estimate against measurement, compound 4: 1.8-fold (0.26 log units) below; the range from low to high includes it.
By their numbers in this assay, from the lowest: compounds 2, 3, 4 and 1 (each within the scatter of the next, the first and the last beyond it).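

For the compounds shown here, the first same-atom exchange, 3-fluorophenyl in place of 2-fluorophenyl on a carbonyl carbon, gives a 1.5-fold higher number from compound 3 to compound 4 (0.19 log units; within the scatter) in this assay. The two fluorophenyl isomers are therefore not separated by this read-out, so the fluoro group's place on this ring has no effect here that exceeds the scatter. Nothing available bears on a reason for this result.

Open, from the compounds shown here alone, is whether chloro or a carboxylic acid in place of the fluoro of 3-fluorophenyl would give a step beyond the scatter. Also open, going by these compounds, is whether butoxy and dimethylamino would keep their earlier difference there.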